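The source may report more compounds than this note shows. Statements on the series, on what has been measured and on what is new or still open speak of the compounds shown alone.

In a functional assay on KBVIN cells (Homo sapiens) for antiproliferative activity, read by sulforhodamine B assay, with a stated time of 3 days (on this read-out higher numbers stand for weaker inhibition of growth and lower numbers for stronger inhibition of growth), three compounds have been measured so far. Compound 1 (`O=C(Nc1ccc(C(F)(F)F)cc1)c1cccc(Nc2ncc(F)c(Nc3ccc(F)cc3)n2)c1`) gives > 10000 nM, which is a limit of the assay. Compound 3 (`O=C(Nc1cccc(Nc2ncc(F)c(Nc3ccc(F)cc3)n2)c1)c1ccccc1`) gives > 10000 nM, also a limit and not a number. Among the measured compounds shown here, compound 2 (`O=C(Nc1cccc(Nc2ncc(F)c(Nc3ccc(F)cc3)n2)c1)c1cnccn1`) is the only one with a number, at 20100 nM. For the measured compounds named here, the one measured step, a step that the limit leaves unreadable from compound 2 to compound 3, offers no size to carry forward. The change leading to compound 4 (`Cn1ccnc1NC(=O)c1cccc(Nc2ncc(F)c(Nc3ccc(F)cc3)n2)c1`) is this: (1-methyl-1H-imidazol-2-yl)carbamoyl in place of benzamido on an aromatic carbon. With compound 2 at 20100 nM, growth inhibition in compound 4 is expected to remain weak in this assay. The estimated step is a step that the limit leaves unreadable from compound 3 to compound 4, and no clear change in either direction is expected. The estimate for compound 4 is 15000 nM, with an expected range from 6000 nM to 40000 nM.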

Compound 4, concentration for 50% growth inhibition: 13100 nM
The estimate for compound 4 lay 1.1-fold (0.06 log units) above the measured number, within the range that was stated.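

In this assay, compound 4 gives a second readable number for a group at this place, and the exchange of ((pyrazin-2-yl)carbonyl)amino for (1-methyl-1H-imidazol-2-yl)carbamoyl is a 1.5-fold lower number from compound 2 to compound 4 (0.19 log units; within the scatter). The two groups therefore cannot be told apart in this read-out. The steps involving compound 1 and compound 3 cannot be read, because those compounds stand at a limit: the limit of > 10000 nM in this assay, at which 2 of the 4 values shown sit.

Going by these compounds, it remains open whether an amine or a carboxylic acid on the amide-type nitrogen would carry the number beyond the scatter. A longer chain there is equally untested by the compounds shown.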